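The compounds below may be only part of what the source reports. "The series", "measured", "known", "first", "only" and "open" are said of these compounds alone.

Measured compounds:
compound 1, `CCN1CCc2c(sc(NC(=O)Nc3ccc(Cl)cc3)c2C(N)=O)C1`: 3120 nM
compound 2, `CCN1CCc2c(sc(NC(=O)CN3CCCCC3)c2C(N)=O)C1`: a limit only, > 25000 nM

Among the measured compounds shown here, in a functional assay (strain AB) with Danio rerio as the target, read by microscopy, with a stated time of 1 h (a higher number here means that more compound is needed for the effect, a lower number that less compound is needed), compound 1 gives 3120 nM, the only plain number in the set. Compound 2 reaches only the limit of the assay, > 25000 nM. For the measured compounds named here, the single measured step, an at least 8.0-fold higher number from compound 1 to compound 2 (0.90 log units; beyond the scatter), concerns the substituent on the carbonyl carbon, and the evidence for it is the limit of > 25000 nM in this assay, at which 1 of the 2 values shown sits.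

Compound 3, `CC(C)(C)OC(=O)CCCCN1CCc2c(sc(NC(=O)Nc3ccc(Cl)cc3)c2C(N)=O)C1`, is yet to be measured in this assay. It differs from compound 1 elsewhere: 2-(tert-butoxycarbonyl)ethyl in place of hydrogen on a saturated chain carbon, two bonds along the chain from an amine nitrogen in a ring. Going by the values given here, no measured step touches this place, so the step from compound 1 to compound 2 offers no direct guide, and the (4-chlorophenyl)amino on the carbonyl carbon is kept unchanged. Compound 3 is therefore expected to stay near compound 1, with no step beyond the scatter: a 1.0-fold lower number from compound 1 to compound 3 (0.02 log units; within the scatter). The estimate for compound 3 is 3000 nM, within 1000 nM to 10000 nM.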

Compound 3, half-maximal effective concentration: 710 nM
The estimate for compound 3 lay 4.2-fold (0.63 log units) above the measured number, outside the stated range (below it).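

The earlier pair spoke only to the substituent on the carbonyl carbon; this place, on a saturated chain carbon, two bonds along the chain from an amine nitrogen in a ring, also affects the result in this assay, with a 4.4-fold lower number from compound 1 to compound 3 (0.64 log units; beyond the scatter) when 2-(tert-butoxycarbonyl)ethyl replaces hydrogen. The added chain and ester therefore do not cost activity here, and less compound is needed with the (4-chlorophenyl)amino group kept. Nothing measured here gives a reason for this step.

Open, on these data alone, is which part of the added group matters: the chain alone, the tert-butyl ester, or the carbonyl, as a carboxylic acid, an amine or a shorter or longer chain at this place would show. Also open, as far as these compounds go, is whether the gain carries over to the (piperidin-1-yl)methyl series of compound 2, which has only a limit.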